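Phenoxy swap on the shared core: compound 1 to compound 4

The compounds below may be only part of what the source reports. "The series", "measured", "known", "first", "only" and "open" are said of these compounds alone.

Compound 1 `Nc1cc(N)c2nc(-c3ccccc3)c(Oc3ccc(Cl)c(Cl)c3)nc2c1` is recorded in a functional assay on 786-0 cells (Homo sapiens) for inhibition, read by sulforhodamine B assay, with a stated time of 48 h (on this read-out lower numbers stand for higher toxicity in this test and higher numbers for lower toxicity in this test), only as a limit, < 100000 nM, one of the recorded values resting at that limit (the limit of < 100000 nM in this assay, at which 1 of the 3 values shown sits). Compound 2 `COc1ccc(CNc2nc3cc(N)cc(N)c3nc2-c2ccccc2)cc1OC` gives 75900 nM in the same test. Compound 3 `COc1cc(CNc2nc3cc(N)cc(N)c3nc2-c2ccccc2)cc(OC)c1OC` is likewise known only as a limit, < 50200 nM (the limit of < 50200 nM in this assay, at which 1 of the 3 values shown sits). Among the measured compounds shown here, the single measured step, an at least 1.5-fold lower number from compound 2 to compound 3 (0.17 log units; that floor lies within the scatter), concerns a methoxy and not the phenoxy group. Compound 4 `Nc1cc(N)c2nc(-c3ccccc3)c(Oc3ccc(F)cc3)nc2c1` differs from compound 1 by 4-fluorophenyl in place of 3,4-dichlorophenyl on an oxygen on an aromatic ring. For the measured compounds named here, no measured pair covers a change of this kind, so the step that the limit leaves unreadable from compound 1 to compound 4 is expected to stay within the scatter. Compound 4 is accordingly estimated at 60000 nM, with a range from 20000 nM to 150000 nM, and a limit rather than a number remains likely.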

Compound 4, concentration lethal to 50% of the cells: 75900 nM
Estimate against measurement, compound 4: 1.3-fold (0.10 log units) below; measured number inside the range.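

No step from compound 1 to compound 4 can be read, because compound 1 stands only as a limit: the limit of < 100000 nM in this assay, at which 1 of the 4 values shown sits.

Going by these compounds, whether 4-fluorophenyl in place of 3,4-dichlorophenyl shifts the number at all, and in which direction, stays open.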